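The source may report more compounds than this note shows. Statements on the series, on what has been measured and on what is new or still open speak of the compounds shown alone.

In an ADME assay on MT4 cells (Homo sapiens) for cytotoxicity, read by MTT assay, with a stated time of 5 days (a higher number here means that more compound is tolerated, a lower number that less compound is tolerated), compound 1 `N#Cc1ccc(Nc2nccc(OCC(=O)Nc3ccc([N+](=O)[O-])cc3)n2)cc1`, which carries a 4-nitrophenyl, reads > 320000 nM, a limit of the assay. Compound 2 `Cc1cnc(Nc2ccc(C#N)cc2)nc1OCC(=O)Nc1ccccc1F` reads > 331000 nM, also a limit. Among the compounds with values here, compound 3 `Cc1cnc(Nc2ccc(C#N)cc2)nc1OCC(=O)Nc1cccc(Cl)c1` gives 144000 nM, the only actual number of the three. Compound 4 `Cc1cnc(Nc2ccc(C#N)cc2)nc1OCC(=O)Nc1ccc([N+](=O)[O-])cc1` has 4-nitrophenyl in place of 3-chlorophenyl on an amide-type nitrogen. Within the data shown here, the one measured step at that nitrogen is an at least 2.2-fold lower number from compound 2 to compound 3 (0.36 log units; beyond the scatter), and its true size is open since it starts from a limit. Compound 1 likewise stands at its limit of > 320000 nM. Only a small step is therefore expected in this assay, if anything toward more compound tolerated, a 1.5-fold higher number from compound 3 to compound 4 (0.16 log units; within the scatter). For compound 4 the estimated value is 210000 nM, with an expected range of 80000 nM to 400000 nM.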

Compound 4, half-maximal cytotoxic concentration: 66300 nM
Compound 4: middle estimate off by 3.2-fold (0.50 log units), on the high side; the measured number lies below the stated range.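

In this assay, the change at the amide-type nitrogen gives a 2.2-fold lower number from compound 3 to compound 4 (0.34 log units; beyond the scatter), so 4-nitrophenyl does not leave the number near the top of the range, as compound 1 alone might have suggested. Set against 2-fluorophenyl at the same nitrogen, it gives an at least 4.9-fold lower number from compound 2 to compound 4 (0.69 log units; beyond the scatter), a step whose true size is open as it starts from a limit: the limit of > 331000 nM in this assay, at which 1 of the 4 values shown sits. With 4-nitrophenyl kept, methyl on an aromatic carbon gives an at least 4.8-fold lower number from compound 1 to compound 4 (0.68 log units; beyond the scatter), which also starts from a limit: the limit of > 320000 nM in this assay, at which 1 of the 4 values shown sits.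

The compounds shown leave open whether the lower number follows the nitro group or its place on the phenyl ring. A 4-chlorophenyl or a 4-aminophenyl at this nitrogen could separate the two.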